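The source may hold more compounds than are shown below. What is called first, only, known or untested is meant among the compounds shown, and "the series" means these compounds.

Four compounds built on one shared core are compared in a functional assay on ZR-75-1 cells (Homo sapiens) for inhibition, read by sulforhodamine B assay; on this read-out higher numbers stand for weaker inhibition of growth and lower numbers for stronger inhibition of growth. Compound 1 `CN(C)c1ccc(-c2ccc(-c3ccc(-c4nc5ccccc5[nH]4)cc3)cc2)cc1` gives 100000 nM. Compound 2 `Clc1cccc(-c2ccc(-c3ccc(-c4nc5ccccc5[nH]4)cc3)cc2)c1` gives 41200 nM; it differs from compound 1 by 3-chlorophenyl in place of 4-(dimethylamino)phenyl on an aromatic carbon, and this change made the step of a 2.4-fold lower number from compound 1 to compound 2 (0.39 log units; beyond the scatter). Compound 3 `CN(C)c1ccc(-c2ccc(-c3ccc(-c4nc5c(O)cccc5[nH]4)cc3)cc2)cc1` gives 4100 nM; its core differs from that of compound 1 by hydroxy in place of hydrogen on an aromatic carbon, the step being a 24-fold lower number from compound 1 to compound 3 (1.39 log units; beyond the scatter). Compound 4 `Oc1cccc2[nH]c(-c3ccc(-c4ccc(-c5cccc(Cl)c5)cc4)cc3)nc12` has not yet been measured. It differs from compound 3 by 3-chlorophenyl in place of 4-(dimethylamino)phenyl on an aromatic carbon, the same change already seen from compound 1 to compound 2. For compound 4 the expected step is a 2.3-fold lower number from compound 3 to compound 4 (0.36 log units; beyond the scatter), because the earlier 2.4-fold lower number from compound 1 to compound 2 (0.39 log units; beyond the scatter) was modest and is assumed to carry over onto the core of compound 3. Compound 4 is therefore estimated at 1800 nM. For compound 4 the expected range runs from 600 nM to 6000 nM.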

Compound 4, concentration for 50% growth inhibition: 2410 nM
Beside the measured number, compound 4's estimate is 1.3-fold (0.13 log units) below it; the range from low to high includes it.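

In this assay putting 3-chlorophenyl in place of 4-(dimethylamino)phenyl gives a 1.7-fold lower number from compound 3 to compound 4 (0.23 log units; within the scatter) and matches the same change on the other core: the same change on two cores in this assay, a 2.4-fold lower number (0.39 log units; beyond the scatter) from compound 1 to compound 2 and a 1.7-fold lower number (0.23 log units; within the scatter) from compound 3 to compound 4, 1.4-fold (0.15 log units) apart, within the scatter of two such steps. Putting hydroxy in place of hydrogen gives a 17-fold lower number from compound 2 to compound 4 (1.23 log units; beyond the scatter) and also carries across, with a large step on both cores: the same change on two cores in this assay, a 24-fold lower number (1.39 log units; beyond the scatter) from compound 1 to compound 3 and a 17-fold lower number (1.23 log units; beyond the scatter) from compound 2 to compound 4, 1.4-fold (0.15 log units) apart, within the scatter of two such steps. The two changes therefore behave alike on both cores among these four compounds, but this does not show that they would do so on any other core, nor why they behave this way.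

The compounds shown leave open whether an amine or a methoxy group in place of the hydroxy would give a step of similar size. They also leave open how a carboxylic acid in place of the 3-chlorophenyl would behave.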